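This account rests on a few compounds, and the source may have more. Where it says the series, first, only, none or still open, it means among the compounds named here.

Measured in a physicochemical assay for solubility, read by chemiluminescence, measured as kinetic solubility; a higher number here means a more soluble compound, a lower number a less soluble compound:
compound 1 `COc1nn(C)c2ncnc(NS(=O)(=O)c3cccc(Cl)c3Cl)c12`: >= 581000 nM, a limit
compound 2 `COCCn1nc(OC)c2c(NS(=O)(=O)c3cccc(Cl)c3Cl)ncnc21`: >= 442000 nM, a limit
compound 3 `COc1nn(C)c2nc(C)nc(NS(=O)(=O)c3cccc(Cl)c3Cl)c12`: >= 557000 nM, a limit

All three readings are limits, not numbers, so the compounds cannot be ranked. Compound 3 stands at >= 557000 nM, which is a limit. Compound 4 `COc1nc(NS(=O)(=O)c2cccc(Cl)c2Cl)c2c(OC)nn(C)c2n1` carries methoxy in place of methyl on an aromatic carbon, between two ring nitrogen atoms: methoxy in place of methyl on an aromatic carbon. Within the data shown here, two measured steps bear on this, a step that the two limits leave unreadable from compound 1 to compound 3 and a step that the two limits leave unreadable from compound 1 to compound 2, and neither has a readable size. No step beyond the scatter is therefore expected in this assay. The estimated change is an at least 1.1-fold lower number from compound 3 to compound 4 (0.04 log units; that floor lies within the scatter). Compound 4 is expected at 500000 nM, with an estimated range of 250000 nM to 650000 nM.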

Compound 4, solubility: 148000 nM
Compound 4: the middle estimate sits 3.4-fold (0.53 log units) above what was measured, and the stated range ends above it.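

In this assay, among these compounds, this aromatic carbon gives the first readable change: methoxy in place of methyl gives an at least 3.7-fold lower number from compound 3 to compound 4 (0.57 log units; beyond the scatter), and methoxy in place of hydrogen gives an at least 3.9-fold lower number from compound 1 to compound 4 (0.59 log units; beyond the scatter). The earlier steps shown here cannot be read, so methyl and hydrogen at this position stay unranked. The first step is only a floor because the reading of compound 3 is a limit: the limit of >= 557000 nM in this assay, at which 1 of the 4 values shown sits.

Going by these compounds, the true size of both steps remains open. So does whether an amine or a longer alkoxy chain at this position would follow compound 4 or compound 3.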